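Removing an Acetyl Group from a Ring Nitrogen

The source may hold more compounds than are shown below. What is called first, only, known or untested is meant among the compounds shown, and "the series" means these compounds.

Compound 1, `COc1ccc(C2CC(c3cc(OC)c(OC)c(OC)c3)=NN2)cc1OC`: 42000 nM
Compound 2, `COc1ccc(C2CC(c3cc(OC)c(OC)c(OC)c3)=NN2C(C)=O)cc1O`: > 100000 nM

In a functional assay on L1210 cells (Mus musculus) for cytotoxicity, read by MTT assay, with a stated time of 72 h (on this read-out higher numbers stand for weaker inhibition and lower numbers for stronger inhibition), compound 1 gives 42000 nM. For compound 2 only a limit is known, > 100000 nM, which is the limit of > 100000 nM in this assay, at which 1 of the 2 values shown sits. Compound 2 therefore stands at the weak end of the values shown. Compound 3, `COc1ccc(C2CC(c3cc(OC)c(OC)c(OC)c3)=NN2)cc1O`, is not yet measured. It differs from compound 2 by hydrogen in place of acetyl on an amine nitrogen in a ring. Among the measured compounds shown here, no measured pair shows this change on its own, so its size is uncertain. The expected step, an at least 2.5-fold lower number from compound 2 to compound 3 (0.39 log units; beyond the scatter), points toward stronger inhibition, since compound 1, with hydrogen on an amine nitrogen in a ring, gives 42000 nM. Compound 3 is estimated at 40000 nM, within 10000 nM to 150000 nM.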

Compound 3, half-maximal inhibitory concentration: 500 nM
Compound 3: middle estimate off by 80-fold (1.90 log units), on the high side; the whole stated range lies above it.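

Hydrogen in place of acetyl on the amine nitrogen in the ring gives an at least 200-fold lower number from compound 2 to compound 3 (2.30 log units; beyond the scatter) in this assay, so strong inhibition here depends on what this nitrogen carries. The value of compound 2 is a limit, not a number: the limit of > 100000 nM in this assay, at which 1 of the 3 values shown sits.

Hydrogen in place of methyl on an oxygen on an aromatic ring gives an 84-fold lower number from compound 1 to compound 3 (1.92 log units; beyond the scatter), so among these compounds strong inhibition appears only when the ring nitrogen carries hydrogen and the hydroxyl is also present.

Still open, from the compounds shown here alone, is whether a methyl or a longer chain on that nitrogen would keep this inhibition. Also open, going by these compounds, is whether an amine could replace the hydroxyl.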